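The compounds below may be only part of what the source reports. "The series", "measured", "known", "first", "only" and "open" are said of these compounds alone.

Measured so far in an ADME assay on MDBK cells (Bos taurus) for cytotoxicity, read by MTT assay, with a stated time of 96 h; a higher number here means that more compound is tolerated, a lower number that less compound is tolerated:
- Compound 1 `Clc1cccc(/N=N/N2CCCC2)c1` gives > 100000 nM (a limit)
- Compound 2 `CN(C)CCCN(/N=N/c1ccc([N+](=O)[O-])cc1)c1ccccc1` gives 39000 nM
- Compound 3 `CN(/N=N/c1ccccc1)c1ccccc1` gives > 100000 nM (a limit)

Going by the values given here, the series so far is marked by the limit of > 100000 nM in this assay, at which 2 of the 3 values shown sit. Compound 1 stands on that limit, so it offers no exact number as a starting point. Compound 2 is the only one of the three with a measured number.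

Next in line is compound 4 `FC(F)(F)c1cccc(/N=N/N2CCCC2)c1`, which has trifluoromethyl in place of chloro on an aromatic carbon of the core of compound 1: trifluoromethyl in place of chloro on an aromatic carbon. Among the compounds with values here, no measured pair shows what this exchange does. No step beyond the usual scatter is therefore expected in this assay, and a limit is again the likeliest report. Should a number appear, a lower reading is the more likely direction, since compound 2 shows that a measurable value of 39000 nM can occur in this set. The expected step is an at least 1.1-fold lower number from compound 1 to compound 4 (0.04 log units; that floor lies within the scatter), and it carries the uncertainty of starting from a limit. For compound 4 the estimate is 90000 nM, with an expected range from 40000 nM to 150000 nM.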

Compound 4, half-maximal cytotoxic concentration: > 100000 nM
Compound 4: a limit, no number; the forecaster's own chance of this, stated with the estimate: 65%; at least 1.1-fold (0.04 log units) between middle value and limit.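

In this assay compound 4 gives > 100000 nM, a limit and not a number. Compound 1 also stands on a limit, so no step can be read between compound 1 and compound 4. The compounds shown leave open what trifluoromethyl in place of chloro does to the tolerated concentration, as the values mostly sit on one mark: the limit of > 100000 nM in this assay, at which 3 of the 4 values shown sit.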